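Notes on a three-compound growth-inhibition series

This account rests on a few compounds, and the source may have more. Where it says the series, first, only, none or still open, it means among the compounds named here.

Measured in a functional assay on HT-29 cells (Homo sapiens) for cytotoxicity, read by MTT assay, with a stated time of 72 h; a higher number here means a weaker inhibitor of growth, a lower number a stronger inhibitor of growth:
compound 1, `CS/C(=N\C(=O)c1cc2ccccc2s1)NC(=O)c1cc2ccccc2s1`: 16800 nM
compound 2, `O=C(/N=C(/NC(=O)c1cccs1)[Se]Cc1ccccc1)c1cccs1`: 55100 nM
compound 3, `CS/C(=N\C(=O)c1cccs1)NC(=O)c1cccs1`: 77900 nM

Compound 4, `O=C(/N=C(/NC(=O)c1cc2ccccc2s1)[Se]Cc1ccccc1)c1cc2ccccc2s1`, has not been measured in this assay.

Compound 1 gives the lowest number of the three; its gaps to compound 2 and to compound 3 both lie beyond the scatter. The difference between the core of compound 1 and the core of compound 3 is not broken down here.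

Compound 3 and compound 2 differ by a group of 8 heavy atoms (7 carbon, 1 selenium; one six-membered aromatic ring of carbon only) in place of a group of 2 heavy atoms (1 carbon, 1 sulfur; no ring), on a carbon with a double bond to nitrogen. In this assay this gives a 1.4-fold lower number from compound 3 to compound 2 (0.15 log units; within the scatter), a step that stays within the scatter.

Compound 1 and compound 4 differ by a group of 8 heavy atoms (7 carbon, 1 selenium; one six-membered aromatic ring of carbon only) in place of a group of 2 heavy atoms (1 carbon, 1 sulfur; no ring), on a carbon with a double bond to nitrogen, the same change as from compound 3 to compound 2, on the same place. The step from compound 1 to compound 4 is expected to be a 1.3-fold lower number from compound 1 to compound 4 (0.11 log units; within the scatter), resting only on the earlier step of a 1.4-fold lower number from compound 3 to compound 2 (0.15 log units; within the scatter), which was small. Among the compounds with values here, with no second example of the change, the estimate carries a wide range.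

Compound 4 is estimated at 13000 nM, between 5000 nM and 35000 nM.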

Compound 4, concentration for 50% growth inhibition: 6510 nM
Estimate against measurement, compound 4: 2.0-fold (0.30 log units) above, within the range that was stated.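

In this assay putting the selenium-bearing group of 8 heavy atoms in place of methylsulfanyl gives a 2.6-fold lower number from compound 1 to compound 4 (0.41 log units; beyond the scatter) on the core of compound 1, a step beyond the scatter, whereas the same change on the core of compound 3 stayed within it. Within the data shown here, two cores are only two examples, so this sets no general rule for the series, fixes no size for the step on a further core, and does not separate the part played by selenium from that of the aromatic ring, which enter together. The two steps cannot be told apart in size, so the change carries from one core to the other without a detectable difference: the same change on two cores in this assay, a 1.4-fold lower number (0.15 log units; within the scatter) from compound 3 to compound 2 and a 2.6-fold lower number (0.41 log units; beyond the scatter) from compound 1 to compound 4, 1.8-fold (0.26 log units) apart, within the scatter of two such steps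

The compounds shown leave open what a plain benzyl-type group with sulfur in place of selenium would give on either core. Also open, on these data alone, are a longer chain in place of methylsulfanyl and an amine or a carboxylic acid on the aromatic ring of the entering group.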